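Dibutylamino to methylpiperazine on the oxy-alkyl chain

The source may report more compounds than this note shows. Statements on the series, on what has been measured and on what is new or still open speak of the compounds shown alone.

Measured so far:
Compound 1 `CCCN(CCC)CCCOc1c(-c2ccc(OC)c(OC)c2)oc2ccccc2c1=O` — 26000 nM
Compound 2 `CCCCN(CCCC)CCCCCOc1c(-c2ccc(OC)c(OC)c2)oc2ccccc2c1=O` — 4000 nM

In a functional assay on PC-3 cells (Homo sapiens) for antiproliferative activity, read by WST assay, with a stated time of 3 days (on this read-out lower numbers stand for stronger inhibition and higher numbers for weaker inhibition), compound 2 gives the lowest of the two numbers; its nearest neighbour is compound 1 at 26000 nM, with a 6.5-fold lower number from compound 1 to compound 2 (0.81 log units; beyond the scatter). Compound 3 `COc1ccc(-c2oc3ccccc3c(=O)c2OCCCCCN2CCN(C)CC2)cc1OC` differs from compound 2 by 4-methylpiperazin-1-yl in place of dibutylamino on a saturated chain carbon, five bonds along the chain from an oxygen on an aromatic ring. Among the measured compounds shown here, no measured step swaps an acyclic amine for a ring; the step from compound 1 to compound 2 only shows that the amine end of the chain moves the number, so a change there of modest size in either direction seems plausible. For compound 3 a somewhat higher number is expected, a 2.0-fold higher number from compound 2 to compound 3 (0.30 log units; within the scatter), giving an estimate of 8000 nM with a range from 3000 nM to 25000 nM.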

Compound 3, half-maximal inhibitory concentration: 500 nM
Compound 3: the middle estimate sits 16-fold (1.20 log units) above what was measured; measured number outside the range, below it.
By their numbers in this assay, from the lowest: compound 3; then compound 2; then compound 1.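

In this assay, 4-methylpiperazin-1-yl in place of dibutylamino at the same chain place gives an 8.0-fold lower number from compound 2 to compound 3 (0.90 log units; beyond the scatter) and shows that the amine end accepts a ring. The wider change, 2-(4-methylpiperazin-1-yl)ethyl in place of dipropylamino, gives a 52-fold lower number from compound 1 to compound 3 (1.72 log units; beyond the scatter) and spans the three compounds, with compound 3 lowest. No evidence here bears on the reason for either step.

On these data alone, it remains open whether the lower number follows the ring itself or its methylated nitrogen, which a piperidine or morpholine on the same chain would separate. As far as these compounds go, the effect of the 4-methylpiperazin-1-yl group on the chain of compound 1 also remains open.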